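The source may report more compounds than this note shows. Statements on the series, on what has been measured and on what is new or still open speak of the compounds shown alone.

Measured so far, in a functional assay on CHO cells for antagonist activity at adenosine receptor A2b (Homo sapiens); on this read-out higher numbers stand for weaker inhibition and lower numbers for stronger inhibition:
Compound 1 `CCCn1cnc2ncnc(N)c21` gives > 30000 nM, which is a limit of the assay and not a number.
Compound 2 `CC(C)n1cnc2c(N)ncnc21` gives 16000 nM.
Compound 3 `CC(C)Cn1cnc2c(N)ncnc21` gives > 30000 nM, again a limit of the assay rather than a number.

Compound 3 therefore stands at the limit of > 30000 nM in this assay, at which 2 of the 3 values shown sit, and its true number is not known. Compound 4 `Nc1ncnc2c1ncn2C1CCC1` differs from it by cyclobutyl in place of isobutyl on an aromatic nitrogen. Among the measured compounds shown here, only one measured step concerns this place: an at least 1.8-fold higher number from compound 2 to compound 3 (0.27 log units; that floor lies within the scatter), a floor that lies within the usual scatter. Both changes trade one small carbon group for another of equal size. No step beyond the scatter is expected for compound 4, which is estimated to sit at or near the limit. The estimate for compound 4 is 30000 nM, with a range from 10000 nM to 100000 nM. This corresponds to an expected step of a number no higher from compound 3 to compound 4 (the limit leaves the size open).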

Compound 4, inhibition constant: 17000 nM
For compound 4 the middle estimate is 1.8-fold (0.25 log units) above the measured one, within the range that was stated.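

Cyclobutyl on this aromatic nitrogen gives a measured number in this assay, and its exchange for isobutyl reads as an at least 1.7-fold lower number from compound 3 to compound 4 (0.24 log units; that floor lies within the scatter). Compound 3 has only a limit, and that step is only a floor: the limit of > 30000 nM in this assay, at which 2 of the 4 values shown sit. Cyclobutyl and isopropyl cannot be told apart here, with a 1.1-fold higher number from compound 2 to compound 4 (0.03 log units; within the scatter).

On these data alone, whether a larger ring such as cyclopentyl would move the number beyond the scatter stays open. So does the effect of a chain ending in an amine at this nitrogen.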